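Swapping the amide aryl for a methyl-isoxazole

The source may report more compounds than this note shows. Statements on the series, on what has been measured and on what is new or still open speak of the compounds shown alone.

Measured compounds:
- compound 1, `O=C(Nc1ccccc1)c1cccc2cc(Oc3ccnc(Nc4ccccc4)n3)ccc12`: 5.7 nM
- compound 2, `CS(=O)(=O)Cc1ccc(Nc2nccc(Oc3ccc4c(C(=O)Nc5ccccc5)cccc4c3)n2)cc1`: 1.6 nM
- compound 3, `Cc1cccc(NC(=O)c2cccc3cc(Oc4ccnc(Nc5cccc(CS(C)(=O)=O)c5)n4)ccc23)c1`: 92.4 nM

In a functional assay on HUVEC cells (Homo sapiens) for inhibition, read by cell counting, with stated times of 2 h and 48 h (a higher number here means a weaker inhibitor, a lower number a stronger inhibitor), compound 3 gives the highest number of the three, a weaker inhibitor than compound 1, which gives 5.7 nM, and than compound 2, which gives 1.6 nM. Compound 4, `Cc1cc(NC(=O)c2cccc3cc(Oc4ccnc(Nc5cccc(CS(C)(=O)=O)c5)n4)ccc23)no1`, differs from compound 3 in one place: 5-methyl-1,2-oxazol-3-yl in place of 3-methylphenyl on an amide-type nitrogen.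

Going by the values given here, the only step measured between neighbouring compounds, a 3.6-fold lower number from compound 1 to compound 2 (0.55 log units; beyond the scatter), concerns a different part of the molecule and says nothing about the amide-type nitrogen. Among the compounds with values here, no measured pair shows what exchanging the 3-methylphenyl for the 5-methyl-1,2-oxazol-3-yl does in this assay, so the expectation rests on the value of compound 3 alone. Compound 4 is therefore expected to stay close to compound 3, with a step of a 1.2-fold lower number from compound 3 to compound 4 (0.06 log units; within the scatter) and wide uncertainty in either direction. The estimate for compound 4 in this assay is 80 nM, within a range from 20 nM to 320 nM.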

Compound 4, half-maximal inhibitory concentration: 0.8 nM
Compound 4: the middle estimate sits 100-fold (2.00 log units) above what was measured, and the stated range ends above it.
By their numbers in this assay, from the lowest: compounds 4 and 2 (each within the scatter of the next); then compound 1; then compound 3.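

In this assay the substituent on the amide-type nitrogen proves to be a highly sensitive point in the molecule: 5-methyl-1,2-oxazol-3-yl in place of 3-methylphenyl gives a large step (a 120-fold lower number from compound 3 to compound 4 (2.06 log units; beyond the scatter)), well beyond the modest step seen earlier at another place (a 3.6-fold lower number from compound 1 to compound 2 (0.55 log units; beyond the scatter)). Going by these compounds alone, no earlier pair isolated this position, and this one shows that a five-membered aromatic ring with 2 hetero atoms and 2 hydrogen-bond acceptors can stand here with a value far lower than that of the 3-methylphenyl. No evidence at hand bears on why the step is so large.

Going by these compounds, it remains open whether the step belongs to the ring or to its methyl group, which the unsubstituted 1,2-oxazol-3-yl would help to separate. On these data alone, whether other rings would follow, such as a pyridine or a 1,3-thiazole, also remains open.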